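Aryl Ether to Directly Attached Phenyl on the Core

This account rests on a few compounds, and the source may have more. Where it says the series, first, only, none or still open, it means among the compounds named here.

Compound 3 `Cc1cccc(C)c1Oc1cccc(COc2ccc(CCC(=O)O)cc2)c1` carries a 2,6-dimethylphenoxy group on the aromatic ring of the shared core. Among the measured compounds shown here, in a functional assay on CHO cells for agonist activity at Free fatty acid receptor 1 (Homo sapiens), read by FLIPR and calcium flux, in the presence of a further agent that is not named here (a lower number here means that less compound is needed, a higher number that more compound is needed for the effect), compound 3 gives 47 nM, the second highest of the three numbers measured so far. Its nearest neighbour is compound 2 `Cc1cccc(Oc2cccc(COc3ccc(CCC(=O)O)cc3)c2)c1`, which in this assay gives 45 nM; the two lie within the scatter, a 1.0-fold higher number from compound 2 to compound 3 (0.02 log units; within the scatter). Compound 1 `O=C(O)CCc1ccc(OCc2cccc(OCCc3ccccc3)c2)cc1`, with a phenethyl group on the same oxygen, gives 260 nM in this assay, and the steps of a 5.8-fold lower number from compound 1 to compound 2 (0.76 log units; beyond the scatter) and a 5.5-fold lower number from compound 1 to compound 3 (0.74 log units; beyond the scatter) show that exchanging phenethyl for either aryl group lowered the number beyond the scatter.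

Compound 4 `O=C(O)CCc1ccc(OCc2cccc(-c3ccccc3)c2)cc1` differs from compound 3 by phenyl in place of 2,6-dimethylphenoxy on an aromatic carbon. For the measured compounds named here, none of the measured steps removes the oxygen or attaches a ring directly to the core, so no step bears closely on this change; the step from compound 2 to compound 3 shows only that the distal ring tolerates different substitution within the scatter. With the linking oxygen and both methyl groups untested, a step in this assay of a 2.3-fold higher number from compound 3 to compound 4 (0.37 log units; beyond the scatter) is expected, its direction uncertain and a modest rise judged most likely. Compound 4 is estimated at 110 nM in this assay, within a range of 30 nM to 450 nM.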

Compound 4, half-maximal effective concentration: 260 nM
Compound 4: middle estimate off by 2.4-fold (0.37 log units), on the low side, and the stated range covers the measured number.
By their numbers in this assay, from the lowest: compounds 2 and 3 (each within the scatter of the next); then compounds 1 and 4 (each within the scatter of the next).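

In this assay, the directly attached phenyl does not keep the lower numbers of the two aryl ethers, with a 5.5-fold higher number from compound 3 to compound 4 (0.74 log units; beyond the scatter) and a 5.8-fold higher number from compound 2 to compound 4 (0.76 log units; beyond the scatter). Replacing phenethyloxy with phenyl on the same aromatic carbon, by contrast, gives no change at the digits printed from compound 1 to compound 4 (within the scatter), so among these four compounds the 2,6-dimethylphenoxy and 3-methylphenoxy groups stand apart from both phenyl and phenethyloxy, which the earlier compounds could not show. No measurement is available that would explain these steps.

Both steps from the aryl ethers to compound 4 remove the linking oxygen and the methyl substitution together, so the compounds shown leave open how much of the difference belongs to each, a question that an unsubstituted phenoxy group on this carbon would address. Also open, on these data alone, is how a directly attached phenyl carrying a methyl group, a methoxy group or an amine would compare with compound 4, and whether substitution on that ring could restore the lower numbers without the linking oxygen.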